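Benzyl arm: methyl in place of methoxy

The source may report more compounds than this note shows. Statements on the series, on what has been measured and on what is new or still open speak of the compounds shown alone.

Working notes on the benzyl arm of the shared core. Compound 1 `CC(C(=O)NCc1ccc(C(F)(F)F)nc1N(Cc1ccc(F)cc1)S(=O)(=O)c1ccc(F)cc1)c1ccc(NS(C)(=O)=O)c(F)c1` gives 0.71 nM in an assay on CHO cells for displacement of a labelled ligand from transient receptor potential cation channel subfamily V member 1 (Homo sapiens), read by scintillation counting, with a stated time of 60 min; a lower number here means a stronger inhibitor, a higher number a weaker inhibitor. For the measured compounds named here, compound 2 `COc1ccc(CN(c2nc(C(F)(F)F)ccc2CNC(=O)C(C)c2ccc(NS(C)(=O)=O)c(F)c2)S(=O)(=O)c2ccc(F)cc2)cc1` gives 1.65 nM in this assay; the only measured step is a 2.3-fold higher number from compound 1 to compound 2 (0.37 log units; beyond the scatter), and compound 2 thus stands at the higher of the two numbers. Compound 3 `Cc1ccc(CN(c2nc(C(F)(F)F)ccc2CNC(=O)C(C)c2ccc(NS(C)(=O)=O)c(F)c2)S(=O)(=O)c2ccc(F)cc2)cc1` differs from compound 2 as follows: methyl in place of methoxy on an aromatic carbon. Going by the values given here, no measured step covers a methyl in this place; the single step to hand, a 2.3-fold higher number from compound 1 to compound 2 (0.37 log units; beyond the scatter), shows that an exchange in this place moved the number only modestly. Compound 1 at 0.71 nM marks the lower end of what this place has shown, so a modest downward move is expected for the new group. The expected step is a 1.5-fold lower number from compound 2 to compound 3 (0.18 log units; within the scatter) in this assay. Compound 3 is estimated at 1.1 nM, with a range from 0.5 nM to 2.5 nM.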

Compound 3, inhibition constant: 3.28 nM
Compound 3: middle estimate off by 3.0-fold (0.47 log units), on the low side; the measured number lies above the stated range.
By their numbers in this assay, from the lowest: compound 1; then compounds 2 and 3 (each within the scatter of the next).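

In this assay, methyl in place of methoxy on the benzyl arm gives (a 2.0-fold higher number from compound 2 to compound 3 (0.30 log units; within the scatter)), so these two groups cannot be told apart at this place. Fluoro now stands apart from both of them, from methyl (a 4.6-fold higher number from compound 1 to compound 3 (0.66 log units; beyond the scatter)) as well as from methoxy (a 2.3-fold higher number from compound 1 to compound 2 (0.37 log units; beyond the scatter)), which makes compound 1 the strongest inhibitor of the three shown. No measurement at hand accounts for this separation of fluoro from the other two groups.

The compounds shown leave open whether chloro or a plain hydrogen at this place would read with fluoro or with methyl and methoxy. Also open, from the compounds shown here alone, are how an amine or a carboxylic acid would read here, and whether the same order holds when other parts of the shared core change.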